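The source may report more compounds than this note shows. Statements on the series, on what has been measured and on what is new or still open speak of the compounds shown alone.

In a functional assay on MCF7 cells (Homo sapiens) for cytotoxicity (on this read-out lower numbers stand for stronger inhibition and higher numbers for weaker inhibition), compound 1 `C=C/C=C\[C@H](C)[C@H](OC(N)=O)[C@@H](C)[C@H](O)[C@@H](C)C/C(C)=C\[C@H](C)[C@@H](O)[C@@H](C)/C=C\CCc1ccc(C)c(F)c1` gives 1000 nM, compound 2 `C=C/C=C\[C@H](C)[C@H](OC(N)=O)[C@@H](C)[C@H](O)[C@@H](C)C/C(C)=C\[C@H](C)[C@@H](O)[C@@H](C)/C=C\CCc1cccc(O)c1C` gives 490 nM and compound 3 `C=C/C=C\[C@H](C)[C@H](OC(N)=O)[C@@H](C)[C@H](O)[C@@H](C)C/C(C)=C\[C@H](C)[C@@H](O)[C@@H](C)/C=C\CCc1ccccc1` gives 480 nM. Compound 3 therefore stands at the low end of this set, and that place is shared: the data show a 1.0-fold lower number from compound 2 to compound 3 (0.01 log units; within the scatter), against a 2.1-fold lower number from compound 1 to compound 3 (0.32 log units; beyond the scatter) and a 2.0-fold lower number from compound 1 to compound 2 (0.31 log units; beyond the scatter), both modest. Compound 4 `C=C/C=C\[C@H](C)[C@H](OC(N)=O)[C@@H](C)[C@H](O)[C@@H](C)C/C(C)=C\[C@H](C)[C@@H](O)[C@@H](C)/C=C\CCc1cc(O)cc(O)c1` differs from compound 3 by 3,5-dihydroxyphenyl in place of phenyl on a saturated chain carbon, two bonds along the chain from a double-bonded chain carbon. No measured ring carries two hydroxy groups, so the evidence is indirect, but the ring changes so far have stayed modest or smaller. A modest rise at most is therefore expected, and the estimated change, a 1.3-fold higher number from compound 3 to compound 4 (0.10 log units; within the scatter), is not expected to pass the scatter. For compound 4 the expected value is 600 nM, with an estimated range of 220 nM to 1600 nM.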

Compound 4, half-maximal inhibitory concentration: 160 nM
Compound 4: the middle estimate sits 3.8-fold (0.57 log units) above what was measured, outside the stated range (below it).
By their numbers in this assay, from the lowest: compound 4; then compounds 3 and 2 (each within the scatter of the next); then compound 1.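

Going by these compounds alone, the ring on this saturated chain carbon can shift the number further than the earlier compounds showed: 3-hydroxy-2-methylphenyl and phenyl stood within the scatter of each other, whereas 3,5-dihydroxyphenyl does not (a 3.0-fold lower number from compound 3 to compound 4 (0.48 log units; beyond the scatter); a 3.1-fold lower number from compound 2 to compound 4 (0.49 log units; beyond the scatter)). The widest step in this assay now also ends at this ring (a 6.3-fold lower number from compound 1 to compound 4 (0.80 log units; beyond the scatter)). As far as these compounds go, whether both hydroxy groups are needed stays open, as does whether a 3-hydroxyphenyl, 3,5-dimethoxyphenyl or 3,5-diaminophenyl ring would do the same. No supporting evidence on offer accounts for this shift.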